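The source may report more compounds than this note shows. Statements on the series, on what has been measured and on what is new or still open speak of the compounds shown alone.

Measured compounds:
Compound 1 `Nc1nc2ccc(OCC(F)(F)C(F)(F)F)cc2s1` — 7.5 mg/kg
Compound 2 `Nc1nc2ccc(OC(F)(F)C(F)F)cc2s1` — 8.5 mg/kg
Compound 3 `C#CCn1c(=N)sc2cc(OC(F)(F)F)ccc21` — 4 mg/kg

In a functional assay on the whole organism with Rattus norvegicus as the target (on this read-out higher numbers stand for an effect only at larger amounts of compound and lower numbers for an effect already at smaller amounts), compound 3 gives 4 mg/kg, the lowest of the three numbers. Its gap to compound 1, which gives 7.5 mg/kg, stays within the usual scatter, so the two cannot be told apart on this read-out. Its gap to compound 2, which gives 8.5 mg/kg, lies just beyond the scatter, so compound 3 sits at a lower dose than compound 2. Going by the values given here, no two measured compounds differ in only one place, so no measured step can be set against the change to compound 4.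

Compound 4 `N=c1sc2cc(OC(F)(F)F)ccc2n1CCS(=O)(=O)O` differs from compound 3 as follows: sulfomethyl in place of ethynyl on a saturated chain carbon bound to an aromatic nitrogen. Among the compounds with values here, the change sits on a saturated chain carbon bound to an aromatic nitrogen, and none of the measured compounds carries a sulfomethyl group there. Within the data shown here, with no step of comparable kind, the direction is a guess; a move toward a higher dose, somewhat beyond the scatter, is expected, as a 2.3-fold higher number from compound 3 to compound 4 (0.35 log units; beyond the scatter). Compound 4 is therefore estimated at 9 mg/kg, within 3 mg/kg to 25 mg/kg.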

Compound 4, dose for half-maximal effect: > 10 mg/kg
Compound 4: only a limit was reported; the forecaster's own chance of this, stated with the estimate: 15%; middle value at least 1.1-fold (0.04 log units) away from the limit.
By their numbers in this assay, from the lowest: compounds 3, 1 and 2 (each within the scatter of the next, the first and the last beyond it). At a limit, above all of these: compound 4.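

In this assay, the chain on the aromatic nitrogen turns out to matter: sulfomethyl in place of ethynyl gives an at least 2.5-fold higher number from compound 3 to compound 4 (0.39 log units; beyond the scatter), the first step measured at this place. The value of compound 4 is a limit and not a number, which leaves the step with a lower bound only: the limit of > 10 mg/kg in this assay, at which 1 of the 4 values shown sits.

Propargyl and 2-sulfoethyl are therefore not interchangeable at this place, and compound 3 is the one that acts at the smaller dose.

Going by these compounds alone, the single step swaps both groups at once, leaving it open whether the shift belongs to the loss of ethynyl or to the arrival of sulfomethyl. A carboxylic acid, an amine or a plain ethyl chain on the same saturated chain carbon would help separate these two readings.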